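The compounds below may be only part of what the source reports. "The series", "measured", "known", "first", "only" and "open" are said of these compounds alone.

Measured in a functional assay on the whole organism for antagonist activity, with Mus musculus as the target; on this read-out higher numbers stand for an effect only at larger amounts of compound and lower numbers for an effect already at smaller amounts:
- Compound 1 `CSc1nnc(-c2ccc(F)cc2)n1C`: > 200 mg/kg, a limit
- Compound 2 `Cn1c(-c2ccccc2)nnc1[S+](C)[O-]`: > 100 mg/kg, a limit
- Compound 3 `CSc1nnc(-c2ccc(C)cc2)n1C`: > 100 mg/kg, a limit

None of these compounds has yet given a true number. Compound 3 stands at the limit of > 100 mg/kg in this assay, at which 2 of the 3 values shown sit. Compound 1 stands at the limit of > 200 mg/kg in this assay, at which 1 of the 3 values shown sits.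

Compound 4 `Cc1ccc(-c2nnc([S+](C)[O-])n2C)cc1` differs from compound 3 in one place: a group of 3 heavy atoms (1 carbon, 1 oxygen, 1 sulfur; no ring) in place of a group of 2 heavy atoms (1 carbon, 1 sulfur; no ring), on an aromatic carbon. Going by the values given here, the only measured step that can be compared is a step that the two limits leave unreadable from compound 1 to compound 3. It concerns a different position on the molecule and has no readable size, so it gives no guide here. The group that enters is already present in compound 2, and that compound also reports only a limit.

With no readable step to build on, no clear shift in this assay is expected in either direction, and another limit is slightly more likely than a number. The expected size of the change, a step that the limit leaves unreadable from compound 3 to compound 4, is therefore only a rough estimate. For compound 4 the estimate is 120 mg/kg, with an expected range from 40 mg/kg to 300 mg/kg.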

Compound 4, dose for half-maximal effect: > 200 mg/kg
Compound 4 ended at the assay's limit; the forecaster's own chance of this, stated with the estimate: 55%; middle value at least 1.6-fold (0.22 log units) from the limit.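

Compound 4 gives > 200 mg/kg as a limit and not a number, so its steps from compound 2 and from compound 3 cannot be read. In this assay the compounds shown leave open what true dose any of them would reach, and whether swapping the methylsulfanyl group changes it.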